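Swapping a Silicon Group for a Sulfonamide Arm

The compounds below may be only part of what the source reports. "The series", "measured", "known", "first", "only" and "open" are said of these compounds alone.

Compound 2, `C[Si](C)(C)c1cn(C[C@H](O)[C@H]2OC(=O)C(OCc3ccccc3)=C2OCc2ccccc2)nn1`: 56000 nM
Compound 1, `COc1ccc(-c2cn(C/C=C3\OC(=O)C(OCc4ccccc4)=C3OCc3ccccc3)nn2)cc1`: > 100000 nM

Among the compounds with values here, compound 2 is the only compound here with a number in a functional assay on SW-620 cells (Homo sapiens) for antiproliferative activity, read by MTT assay, with a stated time of 72 h; on this read-out higher numbers stand for weaker inhibition and lower numbers for stronger inhibition; in this assay compound 2 gives 56000 nM. Compound 1 reaches only the limit of the assay, > 100000 nM, so compound 1 offers no number to set against it, and the limit of > 100000 nM in this assay, at which 1 of the 2 values shown sits, is all that is known of it. Compound 3, `O=C1O[C@H]([C@@H](O)Cn2cc(CNS(=O)(=O)c3ccc(Cl)cc3)nn2)C(OCc2ccccc2)=C1OCc1ccccc1`, has not been measured yet. It differs from compound 2 in one place: a group of 12 heavy atoms (7 carbon, 1 nitrogen, 2 oxygen, 1 sulfur, 1 chlorine; one six-membered aromatic ring of carbon only) in place of a group of 4 heavy atoms (3 carbon, 1 silicon; no ring), on an aromatic carbon. Within the data shown here, no step between two measured compounds is known here, so the size and direction of this change cannot be read from earlier results. The step of a 1.4-fold lower number from compound 2 to compound 3 (0.15 log units; within the scatter) is expected to be small, within the scatter or only slightly beyond it. Compound 3 is estimated at 40000 nM, within a range from 10000 nM to 150000 nM.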

Compound 3, half-maximal inhibitory concentration: 18000 nM
The estimate for compound 3 lay 2.2-fold (0.35 log units) above the measured number; the measured number falls inside the stated range.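

Within the data shown here, this is the first step that can be read in this assay: putting the (((4-chlorophenyl)sulfonyl)amino)methyl group in place of the small silicon group on this aromatic carbon gives a 3.1-fold lower number from compound 2 to compound 3 (0.49 log units; beyond the scatter). So this position tolerates a much larger arm with an added aromatic ring, and the number moves towards stronger inhibition, although compound 3, at 18000 nM, still needs a high concentration to act. Nothing measured here tells why the number moved.

The compounds shown leave open which part of the new arm carries the step: the chlorine, the sulfonyl group, the amino hydrogen or the aromatic ring. A plain aminomethyl group at this position, or the same arm with hydrogen in place of the chlorine, would help to separate these parts.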